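A few compounds are considered here, and "the series" means these few. Any claim that something is new, unique, unknown or untested is made for them only; others in the source may bear on it.

Measured compounds: compound 1, `CONC(=O)[C@@H]1CC=C(CCC=C(C)C)C[C@H]1c1ccccc1`, 2700 nM; compound 2, `COC(=O)CCNC(=O)[C@H]1CC=C(CCC=C(C)C)C[C@@H]1c1ccccc1`, 3100 nM.

In an assay on isolated protein for inhibition of Apoptosis regulator Bcl-2 (Homo sapiens), read by fluorescence polarization, with stated times of 5 min and 10 min (a higher number here means a weaker inhibitor, a lower number a stronger inhibitor), compound 1 gives 2700 nM, the lower of the two numbers recorded, while compound 2 gives 3100 nM in this assay. Going by the values given here, the gap between the two lies within the scatter, so nothing separates them, and no single-point step is recorded between them.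

Compound 3, `CC(C)=CCCC1=CC[C@@H](C(=O)Nc2ccc(C(=O)O)cc2)[C@H](c2ccccc2)C1`, is the next compound to be measured. It differs from compound 1 as follows: 4-carboxyphenyl in place of methoxy on an amide-type nitrogen. The two structures differ only at this amide-type nitrogen, and the shared core of compound 1 stays as it is.

Among the compounds with values here, with no measured step to lean on, the expected size of the step can rest only on the change itself. A modest move to a lower number is expected, an estimated step of a 1.8-fold lower number from compound 1 to compound 3 (0.26 log units; within the scatter) in this assay. For compound 3 the estimate is 1500 nM, with a range from 400 nM to 6000 nM.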

Compound 3, inhibition constant: 2200 nM
Compound 3: the middle estimate sits 1.5-fold (0.17 log units) below what was measured; the range from low to high includes it.
By their numbers in this assay, from the lowest: compounds 3, 1 and 2 (each within the scatter of the next).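

In this assay, going by these compounds alone, the first single-place step at this amide-type nitrogen is a 1.2-fold lower number from compound 1 to compound 3 (0.09 log units; within the scatter), with 4-carboxyphenyl in place of methoxy. The position therefore accepts a much larger group carrying a six-membered aromatic ring without the number moving beyond the scatter, so swapping methoxy for this group does not separate compound 3 from compound 1. Nothing available explains why so large a change in the group leaves the number within the scatter.

The compounds shown leave open whether the ring and the carboxylic acid each matter at this nitrogen, which a plain phenyl or a methyl ester of the same acid could separate. They also leave open whether an amine or a longer chain ending in a carboxylic acid would move the number beyond the scatter.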